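A smaller alkyl group in place of piperidine on the core

This account rests on a few compounds, and the source may have more. Where it says the series, first, only, none or still open, it means among the compounds named here.

The series shares the core shown in compound 1 `COc1ccccc1C(=O)NC(=O)Nc1ccc(-c2nccs2)c(C(F)(F)F)c1`. In a physicochemical assay for solubility, in phosphate buffer, at pH 7.4 (on this read-out lower numbers stand for lower solubility and higher numbers for higher solubility), compound 1 gives < 1 ug/mL, which is a limit of the assay and not a number. Compound 2 `COc1ccccc1C(=O)NC(=O)Nc1ccc(N2CCCCC2)c(C(F)(F)F)c1` carries a piperidin-1-yl group in place of the 1,3-thiazol-2-yl group. In this assay compound 2 gives < 1 ug/mL, again a limit rather than a number. The step that the two limits leave unreadable from compound 1 to compound 2 therefore cannot be read. Compound 3 `COc1ccncc1C(=O)NC(=O)Nc1ccc(-c2ccccc2)c(C(F)(F)F)c1` differs from compound 1 in two places and is not joined to it by a single step; in this assay compound 3 gives 6.6 ug/mL. Compound 2 thus stands at the floor of what this assay reports, the point described by the limit of < 1 ug/mL in this assay, at which 2 of the 3 values shown sit.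

Compound 4 `COc1ccccc1C(=O)NC(=O)Nc1ccc(C(C)C)c(C(F)(F)F)c1` has not yet been measured. It differs from compound 2 by isopropyl in place of piperidin-1-yl on an aromatic carbon. Among the compounds with values here, no measured step with a readable size bears on this change; the only neighbouring step, a step that the two limits leave unreadable from compound 1 to compound 2, is unreadable. The expectation for the step in this assay is therefore a small one, not beyond the scatter, in no clear direction. Compound 4 is estimated at 1.5 ug/mL, within 0.5 ug/mL to 5 ug/mL. The expected step of an at least 1.5-fold higher number from compound 2 to compound 4 (0.17 log units; that floor lies within the scatter) is what that estimate means, with a real chance that the assay again reports only a limit.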

Compound 4, solubility: < 1 ug/mL
Compound 4 gave a limit, no number; the forecaster's own chance of this, stated with the estimate: 45%; at least 1.5-fold (0.17 log units) between middle value and limit.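

In this assay compound 4 gives < 1 ug/mL, which is a limit of the assay and not a number. Its steps from compound 1 and from compound 2 therefore cannot be read, and the three compounds stand together at the floor: the limit of < 1 ug/mL in this assay, at which 3 of the 4 values shown sit.

The compounds shown leave open how the thiazolyl, piperidin-1-yl and isopropyl compounds actually compare in solubility.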